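Swapping methoxy for chloro on compound 3

The source may hold more compounds than are shown below. What is called first, only, known or untested is meant among the compounds shown, and "the series" means these compounds.

- compound 1 `COc1ccc(-n2c(SCc3ccc(F)cc3)nnc2-c2cc(OC)c(OC)c(OC)c2)cc1`: 35000 nM
- compound 2 `COc1ccc(-n2c(SCC(=O)c3ccc(F)cc3)nnc2-c2cc(OC)c(OC)c(OC)c2)cc1`: 58300 nM
- compound 3 `COc1ccc(NC(=O)CSc2nnc(-c3cc(OC)c(OC)c(OC)c3)n2-c2ccc(OC)cc2)cc1`: 25800 nM

These numbers come from a functional assay on PC-3 cells (Homo sapiens) for inhibition, read by MTT assay, with a stated time of 48 h; a lower number here means a stronger inhibitor, a higher number a weaker inhibitor. Compound 3 shares the low end of this small set with compound 1, and the gap between them stays within the scatter: a 1.4-fold lower number from compound 1 to compound 3 (0.13 log units; within the scatter). Compound 2 sits clearly apart, although only modestly: a 2.3-fold lower number from compound 2 to compound 3 (0.35 log units; beyond the scatter).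

The next compound, compound 4 `COc1ccc(-n2c(SCC(=O)Nc3ccc(Cl)cc3)nnc2-c2cc(OC)c(OC)c(OC)c2)cc1`, has chloro in place of methoxy on an aromatic carbon, para to a large group: chloro in place of methoxy on an aromatic carbon.

Within the data shown here, no measured step makes this exact swap, so the evidence is indirect. The closest guide is what happened when the whole group on the chain carbon bound to the sulfur was replaced. Those replacements shifted the number only slightly, as in a 1.7-fold higher number from compound 1 to compound 2 (0.22 log units; within the scatter), and the largest of the three steps is the modest one above. A smaller edit at that end of the molecule is therefore expected to give no shift beyond the scatter, and no direction can be favoured. The expected change is a 1.0-fold lower number from compound 3 to compound 4 (0.01 log units; within the scatter). The estimated value for compound 4 is 25000 nM, with an expected range from 11000 nM to 55000 nM.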

Compound 4, half-maximal inhibitory concentration: 6290 nM
For compound 4 the middle estimate is 4.0-fold (0.60 log units) above the measured one; measured number below the stated range.
By their numbers in this assay, from the lowest: compound 4; then compounds 3, 1 and 2 (each within the scatter of the next, the first and the last beyond it).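

Among these compounds, changing only the group on this aromatic carbon, para to a large group, gives a 4.1-fold lower number from compound 3 to compound 4 (0.61 log units; beyond the scatter) in this assay, a larger step than any among the earlier compounds, so this small edit matters more than those whole-group replacements suggested. The (4-chlorophenyl)carbamoyl group also sets compound 4 clearly apart from both 4-fluorophenyl compounds, with a 5.6-fold lower number from compound 1 to compound 4 (0.75 log units; beyond the scatter) and a 9.3-fold lower number from compound 2 to compound 4 (0.97 log units; beyond the scatter) on record. Nothing measured here explains why the swap lowers the number.

As far as these compounds go, whether fluoro, bromo, methyl or an amine at this position would give a number like that of compound 4 stays open, so the shift cannot yet be tied to chloro itself. Also open, from the compounds shown here alone, is whether chloro in place of the methoxy on the 4-methoxyphenyl group attached directly to the core would shift the number too.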